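The compounds below may be only part of what the source reports. "The series", "measured", "known", "first", "only" and "open" are said of these compounds alone.

- compound 1 `Cc1ccc(S/C(=C/c2c[nH]c3ccccc23)C(=O)c2ccc(Br)cc2)cc1`: 10000 nM
- compound 2 `Cc1ccc(S/C(=C/c2c[nH]c3ccc(Cl)cc23)C(=O)c2ccc(Br)cc2)cc1`: 1000 nM

In a functional assay on DU-145 cells (Homo sapiens) for inhibition, read by trypan blue exclusion, with a stated time of 96 h (a higher number here means a weaker inhibitor of growth, a lower number a stronger inhibitor of growth), compound 2 holds the lower number of the two at 1000 nM and is the stronger inhibitor of growth. Compound 3 `Cc1ccc(S/C(=C/c2c[nH]c3ccc(Br)cc23)C(=O)c2ccc(Br)cc2)cc1` differs from compound 2 by bromo in place of chloro on an aromatic carbon and carries bromo in place of chloro on an aromatic carbon. Going by the values given here, the one measured step is a 10-fold lower number from compound 1 to compound 2 (1.00 log units; beyond the scatter) and it brought chloro in place of hydrogen, so it does not measure this exchange. No step beyond the scatter is therefore expected in this assay here. The expected step is a 1.3-fold lower number from compound 2 to compound 3 (0.10 log units; within the scatter) in size. Compound 3 is estimated at 800 nM within an expected range of 250 nM to 2500 nM for this measurement.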

Compound 3, concentration for 50% growth inhibition: 1000 nM
Beside the measured number, compound 3's estimate is 1.3-fold (0.10 log units) below it, within the range that was stated.
By their numbers in this assay, from the lowest: compounds 2 and 3 (each within the scatter of the next); then compound 1.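

In this assay, swapping one halogen for the other gives no change at the digits printed from compound 2 to compound 3 (within the scatter), so the two halogens cannot be told apart here. Bromo in place of hydrogen gives a 10-fold lower number from compound 1 to compound 3 (1.00 log units; beyond the scatter), the same size as the chloro step, a 10-fold lower number from compound 1 to compound 2 (1.00 log units; beyond the scatter), so both halogens separate from hydrogen at this position. Nothing given here explains this result.

The compounds shown leave open whether fluoro, methoxy or an amine on the same carbon would give a similar number. They also leave open whether this step holds with other groups on the rest of the core.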